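Notes on compound 3: hydroxymethyl in place of carboxy

The compounds below may be only part of what the source reports. "The series", "measured", "known", "first", "only" and "open" are said of these compounds alone.

Measured so far:
compound 1 `CCCc1cc(OC)cc(=O)n1Cc1ccc(-c2ccccc2-c2nn[nH]n2)cc1` — 0.24 mg/kg
compound 2 `CCCc1cc(C(=O)O)cc(=O)n1Cc1ccc(-c2ccccc2-c2nn[nH]n2)cc1` — 0.078 mg/kg

In a functional assay on the whole organism with Rattus norvegicus as the target (a lower number here means that less compound is needed, a higher number that more compound is needed for the effect), compound 2 stands at the lowest of the two numbers; the nearest is compound 1, reached by the modest step of a 3.1-fold lower number from compound 1 to compound 2 (0.49 log units; beyond the scatter). Compound 3 `CCCc1cc(CO)cc(=O)n1Cc1ccc(-c2ccccc2-c2nn[nH]n2)cc1` changes the same position once more: hydroxymethyl in place of carboxy on an aromatic carbon. For the measured compounds named here, only that one measured step bears on this change, and it shows the position is responsive. Removing the carboxy is expected to give back part of that step, as a 2.3-fold higher number from compound 2 to compound 3 (0.36 log units; beyond the scatter). For compound 3 the estimate in this assay is 0.18 mg/kg, with a range of 0.07 mg/kg to 0.5 mg/kg.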

Compound 3, dose for 50% inhibition: 0.3 mg/kg
For compound 3 the middle estimate is 1.7-fold (0.22 log units) below the measured one, and the stated range covers the measured number.
By their numbers in this assay, from the lowest: compound 2; then compounds 1 and 3 (each within the scatter of the next).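

In this assay the advantage of carboxy is lost on moving to hydroxymethyl (a 3.8-fold higher number from compound 2 to compound 3 (0.59 log units; beyond the scatter)), even though the two groups have equal counts of hydrogen-bond donors and acceptors. Hydroxymethyl and methoxy cannot be told apart at this position (a 1.3-fold higher number from compound 1 to compound 3 (0.10 log units; within the scatter)), so among these three compounds only carboxy stands apart. Nothing available here explains this difference.

Still open, going by these compounds, is whether a primary amide or an amine on this carbon would match carboxy or stay with hydroxymethyl and methoxy. Also open, on these data alone, is whether a longer chain in place of propyl would change the size of this step.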